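Thiazolyl for pyridyl on the ring nitrogen of compound 1

A few compounds are considered here, and "the series" means these few. Any claim that something is new, unique, unknown or untested is made for them only; others in the source may bear on it.

Compound 1 `O/N=C(\CCN1CCN(c2ccccn2)CC1)c1ccccc1` is an oxime drawn with the E configuration. Going by the values given here, in a functional assay on HEK293 cells with D(4) dopamine receptor (Homo sapiens) as the target, read by FLIPR (a higher number here means that more compound is needed for the effect, a lower number that less compound is needed), compound 1 gives 4.4 nM, the lowest of the two numbers known. Its partner compound 2 `O/N=C(/CCN1CCN(c2ccccn2)CC1)c1ccccc1` is the same molecule drawn Z, and in this assay compound 2 gives 21.7 nM. Among the compounds with values here, the only measured step is a 4.9-fold higher number from compound 1 to compound 2 (0.69 log units; beyond the scatter), and it rests on the fact that compounds 1 and 2 differ only in the configuration as drawn alone.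

Compound 3 `O/N=C(\CCN1CCN(c2nccs2)CC1)c1ccccc1` is the compound still to be measured. Against compound 1 the change is 1,3-thiazol-2-yl in place of pyridin-2-yl on an amine nitrogen in a ring. Within the data shown here, no measured step bears on this change: the one known step concerns the configuration of the double bond, which compound 3 shares with compound 1, and no pair in the set varies the aromatic group on the amine nitrogen in a ring. With nothing to point either way, the expectation is that compound 3 stays close to compound 1 and that any step a 1.4-fold higher number from compound 1 to compound 3 (0.13 log units; within the scatter) lies within the scatter. Compound 3 is therefore estimated to give 6 nM, with a range from 1.5 nM to 25 nM.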

Compound 3, half-maximal effective concentration: 49.5 nM
Beside the measured number, compound 3's estimate is 8.3-fold (0.92 log units) below it, and the stated range ends below it.
By their numbers in this assay, from the lowest: compound 1; then compound 2; then compound 3.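

In this assay, the aromatic group on the amine nitrogen in a ring proves to be a position that the read-out responds to: with the E double bond kept as in compound 1, 1,3-thiazol-2-yl in place of pyridin-2-yl gives an 11-fold higher number from compound 1 to compound 3 (1.05 log units; beyond the scatter). The earlier pair showed only that the configuration of the double bond matters, with a 4.9-fold higher number from compound 1 to compound 2 (0.69 log units; beyond the scatter), whereas this step shows that the group at the far end of the piperazine-free description, the amine nitrogen in a ring, matters as well, and that more compound is needed with the five-membered ring. Going by these compounds alone, the only available evidence concerns configuration and offers no explanation for this change of aromatic group.

The change alters ring size, hetero atom count and the presence of sulfur all at once, so the step cannot be assigned to any one of them; a 1,3-oxazol-2-yl group, a phenyl ring or a pyrimidin-2-yl group on the same nitrogen would help to separate them. Going by these compounds, it also remains open whether the preference for E over Z seen with pyridin-2-yl carries over to compounds bearing 1,3-thiazol-2-yl.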